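The source may hold more compounds than are shown below. What is called first, only, known or untested is meant among the compounds shown, and "the series" means these compounds.

Compound 1 `CC1=CC[C@H](C(C)(C)NC(=S)N/N=C/c2ccccc2O)CC1` is the anchor of this small set. Within the data shown here, in a functional assay on NCI/ADR-RES cells (Homo sapiens) for inhibition, read by sulforhodamine B assay, with a stated time of 48 h (on this read-out higher numbers stand for weaker inhibition of growth and lower numbers for stronger inhibition of growth), compound 1 gives 10900 nM, the only firm number among the two values shown. Compound 2 `CC1=CC[C@H](C(C)(C)NC(=S)N/N=C/c2ccccc2[N+](=O)[O-])CC1` carries a nitro in place of hydroxy on an aromatic carbon. In this assay compound 2 reaches only > 100000 nM, which is a limit of the assay rather than a measured number (the limit of > 100000 nM in this assay, at which 1 of the 2 values shown sits). Among the measured compounds shown here, the step of an at least 9.1-fold higher number from compound 1 to compound 2 (0.96 log units; beyond the scatter) is thus the one measured guide. Compound 3 `CC1=CC[C@H](C(C)(C)NC(=S)N/N=C/c2ccco2)CC1` alters the same carbon differently: furan-2-yl in place of 2-hydroxyphenyl on a carbon with a double bond to nitrogen. Both changes remove the hydroxy group from the ring carbon, so the step to compound 2 bears on this one, and a weakening, a higher number, is expected, though its size is uncertain. For compound 3 the expected value is 35000 nM, within 9000 nM to 100000 nM. This expectation corresponds to a step of a 3.2-fold higher number from compound 1 to compound 3 (0.51 log units; beyond the scatter).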

Compound 3, concentration for total growth inhibition: 14100 nM
Compound 3: middle estimate off by 2.5-fold (0.39 log units), on the high side; low and high end bracket the measured number.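

Swapping 2-hydroxyphenyl for furan-2-yl on the carbon with a double bond to nitrogen gives a 1.3-fold higher number from compound 1 to compound 3 (0.11 log units; within the scatter), so compound 1 and compound 3 cannot be told apart in this assay. Neither the hydroxy group, with its hydrogen-bond donor, nor the six-membered aromatic ring is therefore needed at this place to keep a measurable number, as compound 3 has 0 hydrogen-bond donors and a five-membered ring. Compound 2 also lacks the hydroxy group, so its result, which is a limit of the assay and not a number, cannot be put down to that loss alone: the limit of > 100000 nM in this assay, at which 1 of the 3 values shown sits.

From the compounds shown here alone, whether a thiophene or pyridine ring would match furan-2-yl here remains open. So does the effect of a methoxy or an amine in place of the hydroxy on the phenyl ring.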